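Replacing the (Pyridin-4-yl)methoxy Group of Compound 3

The source may hold more compounds than are shown below. What is called first, only, known or untested is meant among the compounds shown, and "the series" means these compounds.

compound 1, `COc1ccc(-c2csc(N)c2C(=O)OCc2ccc(C)cc2)cc1OC`: 50% in an assay on isolated protein for inhibition of protein kinase C zeta type (Homo sapiens), with stated times of 1 h and 2.5 min, tested at 30 uM; a higher number here means more inhibition at the concentration tested (going by the name of the read-out), a lower number less inhibition
compound 2, `COc1ccc(-c2csc(N)c2C(=O)OCc2ccc(F)cc2)cc1OC`: 2%
compound 3, `COc1ccc(-c2csc(N)c2C(=O)OCc2ccncc2)cc1OC`: 53%

Compound 3 gives the highest of the three numbers, but its gap to compound 1 is within the scatter, a number 3 percentage points higher from compound 1 to compound 3 (within the scatter); only compound 2 stands well apart, a number 51 percentage points higher from compound 2 to compound 3 (beyond the scatter). Compound 4, `COCCNC(=O)c1c(-c2ccc(OC)c(OC)c2)csc1N`, carries (2-methoxyethyl)amino in place of (pyridin-4-yl)methoxy on a carbonyl carbon. Among the measured compounds shown here, none of the measured steps removes that whole group; they swap one ring for another at the same carbonyl-bound position, and there a small change gave a large step, a number 48 percentage points lower from compound 1 to compound 2 (beyond the scatter), while another gave none beyond the scatter. For the measured compounds named here, with no direct precedent, compound 4 is expected to shift by a number 23 percentage points lower from compound 3 to compound 4 (beyond the scatter), most likely downward, and its estimate in this assay is 30%, ranging from 0% to 65%.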

Compound 4, a percentage reported as inhibition, at one concentration (the size of the read-out at that concentration, not a potency): 55%
For compound 4 the middle estimate is 25 percentage points below the measured one; the range from low to high includes it.
By their numbers in this assay, from the lowest: compound 2; then compounds 1, 3 and 4 (each within the scatter of the next).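

In this assay the step of a number 2 percentage points higher from compound 3 to compound 4 (within the scatter) shows that this carbonyl carbon can carry a group with no ring, and the step of a number 5 percentage points higher from compound 1 to compound 4 (within the scatter) reads the same way against (4-methylbenzyl)oxy. With the step of a number 53 percentage points higher from compound 2 to compound 4 (beyond the scatter) as well, only (4-fluorobenzyl)oxy stands apart among the four groups at this carbonyl carbon. Nothing available explains this pattern.

On these data alone, it remains open whether a carboxylic acid or a piperazine amide at this carbonyl carbon would keep the number. As far as these compounds go, it is equally open whether a plain ethylamino chain, without the terminal methoxy, would do so.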